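Compound 2 to compound 3: expected clearance step

The compounds below may be only part of what the source reports. "The series", "measured", "known", "first", "only" and "open" are said of these compounds alone.

Among the measured compounds shown here, in an in vitro ADME assay on microsomes from liver (Homo sapiens) for metabolic stability (on this read-out lower numbers stand for slow clearance and higher numbers for fast clearance), compound 2 (`O=C(C=C1CCN(C(=O)c2ccccc2F)CC1)N[C@@H]1CCN(Cc2ccc3cc(F)ccc3c2)C1`) gives 590 mL/min/kg as the higher of two numbers so far, while compound 1 (`COc1cccc(O)c1C(=O)N1CCC(=CC(=O)N[C@@H]2CCN(Cc3ccc4cc(F)ccc4c3)C2)CC1`) gives 192 mL/min/kg in the same read-out. The change to compound 3 (`COc1cccc(C(=O)N2CCC(=CC(=O)N[C@@H]3CCN(Cc4ccc5cc(F)ccc5c4)C3)CC2)c1O`) puts 2-hydroxy-3-methoxyphenyl in place of 2-fluorophenyl on a carbonyl carbon. For the measured compounds named here, the one measured step bearing on this is a 3.1-fold higher number from compound 1 to compound 2 (0.49 log units; beyond the scatter) with 2-fluorophenyl in place of 2-hydroxy-6-methoxyphenyl, modest but beyond the scatter. A reverse step of similar size is expected, namely a 2.6-fold lower number from compound 2 to compound 3 (0.41 log units; beyond the scatter) towards slower clearance. For compound 3 the estimate is 230 mL/min/kg with 90 mL/min/kg to 520 mL/min/kg as the expected range.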

Compound 3, clearance: 162 mL/min/kg
Estimate against measurement, compound 3: 1.4-fold (0.15 log units) above; the range from low to high includes it.
By their numbers in this assay, from the lowest: compounds 3 and 1 (each within the scatter of the next); then compound 2.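

At this place on a carbonyl carbon, a second hydroxy-methoxy phenyl also stands apart from 2-fluorophenyl in this assay, with a 3.6-fold lower number from compound 2 to compound 3 (0.56 log units; beyond the scatter) as the step. The two hydroxy-methoxy phenyl groups are not told apart, with a 1.2-fold lower number from compound 1 to compound 3 (0.07 log units; within the scatter) as their step, so both arrangements give the same reading here. No measured evidence on hand explains these steps.

Going by these compounds, whether the hydroxy group, the methoxy group or both together carry the step stays open. A plain 2-hydroxyphenyl and a plain 2-methoxyphenyl on the same carbonyl would separate them.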